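A Ring Closure on a Urea Side Chain

The compounds below may be only part of what the source reports. "The series", "measured", "known", "first", "only" and "open" are said of these compounds alone.

Compound 1 `CCNC(=O)Nc1ccc(/C=C\c2cccc(Cl)c2)cc1` gives 32000 nM
Compound 2 `CCNC(=O)Nc1ccc(/C=C\c2cc(C)cc(C)c2)cc1` gives 17000 nM
Compound 3 `CCNC(=O)Nc1ccc(/C=C\c2cc(OC)c(OC)c(OC)c2)cc1` gives 21000 nM

These three values come from a functional assay on MCF7 cells (Homo sapiens) for inhibition, read by sulforhodamine B assay, with a stated time of 48 h (on this read-out lower numbers stand for stronger inhibition and higher numbers for weaker inhibition), and all of them are weak in absolute terms. In this assay compound 2 gives 17000 nM and stands within the usual scatter of both compound 3 and compound 1, so the three cannot be ranked against one another.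

The account now turns to compound 4 `Cc1cc(C)cc(/C=C\c2ccc(N3CCNC3=O)cc2)c1` which keeps the rest of compound 2 but carries 2-oxoimidazolidin-1-yl in place of (ethylcarbamoyl)amino on an aromatic carbon. Going by the values given here, all three measured compounds carry (ethylcarbamoyl)amino, and no measured pair tests this exchange. The measured compounds differ from one another only elsewhere in the structure, and those differences leave compound 1 at 32000 nM and compound 3 at 21000 nM within the scatter of compound 2. That says little about the new group, so the expectation stays cautious and its range wide.

The estimated step of a 1.5-fold higher number from compound 2 to compound 4 (0.17 log units; within the scatter) in this assay is expected to stay within the scatter, leaning if anything toward weaker inhibition. For compound 4 the estimated value is 25000 nM (expected range 10000 nM to 60000 nM)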

Compound 4, half-maximal inhibitory concentration: 23 nM
For compound 4 the middle estimate is 1100-fold (3.04 log units) above the measured one; measured number below the stated range.
By their numbers in this assay, from the lowest: compound 4; then compounds 2, 3 and 1 (each within the scatter of the next).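

In this assay, going by these compounds alone, 2-oxoimidazolidin-1-yl in place of (ethylcarbamoyl)amino gives a 740-fold lower number from compound 2 to compound 4 (2.87 log units; beyond the scatter), so this position, on an aromatic carbon para to a large group, is sensitive to the exchange in a way the earlier compounds could not reveal, since all three carry the same open group and stay within the scatter of one another. The two groups have the same heavy atoms by count; what differs is that the entering group has one five-membered non-aromatic ring and one hydrogen-bond donor, while the leaving group has no ring and 2 hydrogen-bond donors. Nothing available here explains why this exchange has so large an effect.

The compounds shown leave open whether the ring itself or the lost hydrogen-bond donor accounts for the step, and how a methyl group on the ring nitrogen or a six-membered cyclic urea would compare. From the compounds shown here alone, it also remains open whether the same exchange would give a comparable step with the chloro substituent of compound 1 or the three methoxy groups of compound 3.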